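The source may hold more compounds than are shown below. What is called first, only, known or untested is meant among the compounds shown, and "the series" means these compounds.

Compound 1, `CCc1cc(=O)c2ccc(OCc3cccc(C(F)(F)F)c3)c(C)c2o1`, in a functional assay on DU-145 cells (Homo sapiens) for antiproliferative activity, read by sulforhodamine B assay, with a stated time of 72 h (on this read-out lower numbers stand for stronger inhibition of growth and higher numbers for weaker inhibition of growth), gives > 27600 nM, which is a limit of the assay rather than a number.
Compound 2, `CCc1oc2c(C)c(OC)ccc2c(=O)c1Br`, in this assay gives > 33600 nM, again a limit.
Compound 3, `CCc1oc2c(C)c(OCc3ccccc3)ccc2c(=O)c1Br`, in this assay gives > 26700 nM, also a limit.

Compound 3 therefore has no numerical value: it sits at the limit of > 26700 nM in this assay, at which 1 of the 3 values shown sits, and the other two compounds likewise stand at limits. Among the measured compounds shown here, the one single-point step among the measured compounds, a step that the two limits leave unreadable from compound 2 to compound 3, runs between two limits and cannot be sized.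

Compound 4 is `CCc1oc2c(C)c(OCc3cccc(C(F)(F)F)c3)ccc2c(=O)c1Br`. Its difference from compound 3 is trifluoromethyl in place of hydrogen on an aromatic carbon. For the measured compounds named here, compound 1 also carries a trifluoromethyl group on a six-membered aromatic ring of carbon only and shows only a limit in this assay, but no step joins compound 1 to any other compound here, so it gives no readable size either. Going by the values given here, nothing among the measured steps is readable, so the expectation for a step that the limit leaves unreadable from compound 3 to compound 4 is no change beyond the scatter, with the most likely outcome being a further limit. Compound 4 is thus estimated at 40000 nM in this assay, with a range from 12000 nM to 120000 nM.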

Compound 4, concentration for 50% growth inhibition: > 22600 nM
Compound 4: a limit, no number (the forecaster's own chance of this, stated with the estimate: 85%); the middle value is on the limit's open side.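

Compound 4 also stands at a limit rather than a number, like compound 1 and compound 3, and neither of its two new steps, from compound 3 or from compound 1, can be read. The compounds shown leave open what size, if any, the trifluoromethyl and bromo changes have in this assay.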